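Compound 3 to compound 4: methyl on the aryl ring

A few compounds are considered here, and "the series" means these few. Any claim that something is new, unique, unknown or untested is made for them only; others in the source may bear on it.

Three compounds of the shared core have numbers in a functional assay on PANC-1 cells (Homo sapiens) for cytotoxicity, read by MTT assay, with a stated time of 72 h, tested at 10 uM; a higher number here means a weaker effect of the compound at the concentration tested, a lower number a stronger effect. Compound 1 `C=C1C(=O)O[C@@H](c2ccc(OC)cc2)[C@H]1C` gives 32% in this assay. Compound 2 `C=C1C(=O)O[C@@H](c2ccccc2)[C@H]1c1ccccc1` gives 38%. Compound 3 `C=C1C(=O)O[C@H](c2ccccc2)[C@H]1c1ccccc1` gives 1%, the lowest of the three, so the strongest effect at the concentration tested. Within the data shown here, the only one-place step measured is a number 37 percentage points lower from compound 2 to compound 3 (beyond the scatter); the two compounds share all atoms and bonds, and the step rests on the fact that compounds 2 and 3 differ only in the configuration as drawn alone.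

Compound 4 `C=C1C(=O)O[C@H](c2ccc(C)cc2)[C@H]1c1ccccc1` keeps the configuration of compound 3 and differs by methyl in place of hydrogen on an aromatic carbon. Among the measured compounds shown here, no measured step touches a change on the aryl ring; compound 1 carries a different group there but also differs in the other ring substituent and in configuration, so its value gives no isolated reading of a ring substitution. With nothing pointing either way, the step of a number 5 percentage points higher from compound 3 to compound 4 (within the scatter) is expected to stay within the scatter. Compound 4 is therefore estimated at 6%, with a range from 0% to 25%, the lower end set by the floor of the read-out.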

Compound 4, a percentage reported as activity, at one concentration (the size of the read-out at that concentration, not a potency): 0%
Compound 4: middle estimate off by 6 percentage points, on the high side; the measured number falls inside the stated range.
By their numbers in this assay, from the lowest: compounds 4 and 3 (each within the scatter of the next); then compounds 1 and 2 (each within the scatter of the next).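

Methyl in place of hydrogen on an aromatic carbon, para to a large group, gives the first one-place reading at this position: in this assay the step is a number 1 percentage points lower from compound 3 to compound 4 (within the scatter). With the configuration of compound 3 kept, this position therefore tolerates the added methyl without a measurable loss of effect at the concentration tested. Compound 3 at 1% and compound 4 at 0% lie within the scatter of each other, and nothing available gives a cause for this step.

Going by these compounds, whether an amine, a carboxylic acid or a longer chain at this position would keep the number this low remains open. Also open, on these data alone, is how compound 3 and compound 4 compare in potency, which a reading at one concentration cannot separate.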